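Permeability notes on a shared core: compounds 1 to 4

This account rests on a few compounds, and the source may have more. Where it says the series, first, only, none or still open, it means among the compounds named here.

Measured so far in an ADME assay on Caco-2 cells (Homo sapiens) for permeability, in the apical to basolateral direction; on this read-out lower numbers stand for lower permeability and higher numbers for higher permeability:
- compound 1 `CNC(=O)c1cc(Oc2ccc3nc(Nc4cccc(C(C)(C)C)c4)ncc3c2)ccn1` gives < 1 10^-6 cm/s, which is a limit of the assay and not a number.
- compound 2 `CNC(=O)c1cc(Oc2ccc3nc(Nc4ccccc4Br)ncc3c2)ccn1` gives < 1 10^-6 cm/s, also a limit of the assay.
- compound 3 `CCc1ccccc1Nc1ncc2cc(Oc3ccnc(C(=O)NC)c3)ccc2n1` gives < 1 10^-6 cm/s, again a limit of the assay.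

Compound 3 therefore stands at the limit of < 1 10^-6 cm/s in this assay, at which 3 of the 3 values shown sit, and nothing distinguishes it from the other two measured compounds on the numbers shown. The steps among the measured compounds, a step that the two limits leave unreadable from compound 1 to compound 2, a step that the two limits leave unreadable from compound 1 to compound 3 and a step that the two limits leave unreadable from compound 2 to compound 3, cannot be sized, so they give no direction for the next change.

Compound 4 `CNC(=O)c1cc(Oc2ccc3nc(Nc4cccc(C(F)(F)F)c4)ncc3c2)ccn1` differs from compound 3 in one place: 3-(trifluoromethyl)phenyl in place of 2-ethylphenyl on a nitrogen on an aromatic ring. Among the measured compounds shown here, every measured step bears on the same position of the series, yet none is readable, so no step beyond the scatter can be expected in this assay from them, and the three values at the limit are the only guide. Compound 4 is estimated at 0.6 10^-6 cm/s in this assay. The expected range for compound 4 runs from 0.1 10^-6 cm/s to 2.5 10^-6 cm/s. The step expected is a step that the limit leaves unreadable from compound 3 to compound 4, which is no change beyond the scatter, with a high chance that only a limit is reported again.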

Compound 4, apparent permeability: < 1 10^-6 cm/s
Compound 4: no number, only a limit (the forecaster's own chance of this, stated with the estimate: 70%); the middle value is on the limit's open side.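

Compound 4 gives < 1 10^-6 cm/s in this assay, a limit of the assay and not a number, so no new step can be read between it and compound 1, compound 2 or compound 3. The compounds shown leave open how these four differ in this assay, and which change on the shared core would give a readable number.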